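The source may report more compounds than this note shows. Statements on the series, on what has been measured and on what is new or still open speak of the compounds shown alone.

Two compounds in this series share a core in which a chain ends in a ring-bearing carbonyl, and differ only in where an iodine sits on the benzene ring. Compound 1 `O=C(CCCCCc1cccc(I)c1)N1CCOC1=O` carries its iodine at one position; in an assay on HEK293 cells for inhibition of N-acylethanolamine-hydrolyzing acid amidase (Rattus norvegicus), read by LC-MS, with a stated time of 30 min (a lower number here means a stronger inhibitor, a higher number a weaker inhibitor), compound 1 gives 3120 nM. Compound 2 `O=C(CCCCCc1ccc(I)cc1)N1CCOC1=O` carries the iodine at another position. In this assay compound 2 reaches only > 20000 nM, which is a limit of the measurement rather than a number, so compound 2 is known only to sit at the limit of > 20000 nM in this assay, at which 1 of the 2 values shown sits. Among the measured compounds shown here, of the two values shown, compound 2 thus stands at the weaker end, and no step between the two has been computed.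

The next compound, compound 3 `NC(=O)c1ccc(CCCCCC(=O)N2CCOC2=O)cc1`, is derived from compound 2 by a single change: carbamoyl in place of iodo on an aromatic carbon. Because compound 2 in this assay shows only a limit > 20000 nM, there is no firm starting number from which to count a step. The expectation is that the change from compound 2 to compound 3 brings a modest gain, an at least 1.3-fold lower number from compound 2 to compound 3 (0.12 log units; that floor lies within the scatter), yet no more than the scatter clearly separates. In this assay compound 3 is therefore estimated at 15000 nM, somewhere between 3000 nM and 60000 nM.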

Compound 3, half-maximal inhibitory concentration: > 20000 nM
Compound 3 ended at the assay's limit; the forecaster's own chance of this, stated with the estimate: 50%; middle value at least 1.3-fold (0.12 log units) from the limit.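

In this assay compound 3 gives > 20000 nM as a limit of the measurement, not a number. Among the compounds shown here, compound 2 also stands at a limit, so no step from compound 2 to compound 3 can be read: the limit of > 20000 nM in this assay, at which 2 of the 3 values shown sit. The compounds shown leave open whether carbamoyl in place of iodo on an aromatic carbon changes inhibition at all.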